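This account rests on a few compounds, and the source may have more. Where it says the series, first, only, none or still open, it means among the compounds named here.

The measured compounds:
compound 1, `CN1c2ccc(NC(=O)Nc3ccc(N)cc3)cc2C(C)(C)C(=O)C1(C)C`: 1100 nM
compound 2, `CN1c2ccc(NC(=O)Nc3ccc([N+](=O)[O-])cc3)cc2C(C)(C)C(O)C1(C)C`: 1600 nM

Both were tested in an assay on isolated protein for binding affinity to stress-70 protein, mitochondrial (Homo sapiens); a lower number here means tighter binding, a higher number weaker binding. Of the two numbers, compound 2 carries the larger, but the gap to compound 1 lies within the scatter, so the two read as alike. Compound 3, `CN1c2ccc(NC(=O)Nc3ccc(C(F)(F)F)cc3)cc2C(C)(C)C(O)C1(C)C`, has not yet been measured. It differs from compound 2 in one place: trifluoromethyl in place of nitro on an aromatic carbon. Within the data shown here, no step between measured compounds bears on this change, so nothing in the data points to a direction. The step from compound 2 to compound 3 is expected to be small, not beyond the scatter: a 1.1-fold lower number from compound 2 to compound 3 (0.03 log units; within the scatter). Compound 3 is therefore estimated at 1500 nM, within the range 500 nM to 4500 nM.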

Compound 3, dissociation constant: 700 nM
Compound 3: middle estimate off by 2.1-fold (0.33 log units), on the high side; measured number inside the range.
By their numbers in this assay, from the lowest: compounds 3, 1 and 2 (each within the scatter of the next, the first and the last beyond it).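

In this assay, among these compounds, trifluoromethyl in place of nitro on this aromatic carbon gives a 2.3-fold lower number from compound 2 to compound 3 (0.36 log units; beyond the scatter) and so provides the first single-place reading here, showing that the number responds to the group at this position. The earlier compounds shown here differ from each other in more than one place and could not show this. Nothing at hand explains the step.

From the compounds shown here alone, whether a nitrile or a carboxylic acid on this carbon would move the number further remains open. So does whether the same change would give a similar step with the carbonyl of compound 1 on the core.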